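Swapping the Chain Amine in a Cytotoxicity Series

This account rests on a few compounds, and the source may have more. Where it says the series, first, only, none or still open, it means among the compounds named here.

Compound 1 `COc1cc2c(Oc3ccc(NC(=O)c4cc(-c5ccccc5F)ccn4)cc3F)ccnc2cc1OCCCN1CCCCC1` and compound 2 `COc1cc2c(Oc3ccc(NC(=O)c4cc(-c5ccc(C(F)(F)F)cc5)ccn4)cc3F)ccnc2cc1OCCCN1CCCCC1` share one core and differ in a single aromatic group. In a functional assay on NCI-H460 cells (Homo sapiens) for cytotoxicity, read by MTT assay, with a stated time of 72 h (a lower number here means a stronger inhibitor, a higher number a weaker inhibitor), compound 1 gives 130 nM, while compound 2 gives 360 nM. That single change, a 2.8-fold higher number from compound 1 to compound 2 (0.44 log units; beyond the scatter), makes compound 2 the higher of the two numbers shown, with compound 1 the nearest neighbour and a lower number; on these two values compound 2 is the weaker inhibitor.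

Compound 3 `COc1cc2c(Oc3ccc(NC(=O)c4cc(-c5ccc(C(F)(F)F)cc5)ccn4)cc3F)ccnc2cc1OCCCN1CCN(C)CC1` has not yet been measured. It differs from compound 2 at a different place altogether: 4-methylpiperazin-1-yl in place of piperidin-1-yl on a saturated chain carbon, three bonds along the chain from an oxygen on an aromatic ring. Within the data shown here, the only measured step, from compound 1 to compound 2, altered an aromatic group far from this chain, so it does not bear on the present change, and no measured pair probes the chain amine. With nothing comparable to lean on, the expected step is no change at the digits printed from compound 2 to compound 3 (within the scatter), which means no change beyond the scatter. Compound 3 is therefore expected to give about 360 nM in this assay, within a range of 150 nM to 900 nM.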

Compound 3, half-maximal inhibitory concentration: 160 nM
Beside the measured number, compound 3's estimate is 2.3-fold (0.35 log units) above it; the measured number falls inside the stated range.
By their numbers in this assay, from the lowest: compounds 1 and 3 (each within the scatter of the next); then compound 2.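

The chain amine is not a silent position: in this assay, putting 4-methylpiperazin-1-yl in place of piperidin-1-yl gives a 2.3-fold lower number from compound 2 to compound 3 (0.35 log units; beyond the scatter) and so moves the number by a modest step beyond the scatter. Among these compounds, until now only an aromatic group had been varied, and this step is the first sign that a saturated chain carbon, three bonds along the chain from an oxygen on an aromatic ring, is also a place where a change in the attached amine can lower the number in this cell assay. The new group differs from the old by a second ring nitrogen and a methyl group on it, but no measurement shown here accounts for the drop in the number.

On these data alone, whether the step belongs to the second ring nitrogen or to its methyl group stays open, and an unsubstituted piperazine or a morpholine in the same place would help to separate the two. Also open, as far as these compounds go, is whether the same amine exchange acts alike with the 2-fluorophenyl group of compound 1, or on a shorter or longer chain.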